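The source may hold more compounds than are shown below. What is called first, only, known or untested is meant among the compounds shown, and "the series" means these compounds.

Measured compounds in a functional assay on HepG2 cells (Homo sapiens) for antiproliferative activity, read by CCK-8 assay, with a stated time of 72 h, tested at 8 uM; on this read-out higher numbers stand for a stronger effect at the one concentration tested and lower numbers for a weaker effect:

- compound 1, `Nc1ccccc1NC(=O)/C=C/c1ccc(Cn2cnc3c(Nc4ccccc4)nc(Cl)nc32)cc1`, gives 41.9%
- compound 2, `Nc1ccccc1NC(=O)c1ccc(Cn2cnc3c(Nc4ccccc4)nc(Cl)nc32)cc1`, gives 74.8%
- compound 3, `CCCCn1cnc2c(Nc3cccc(Cl)c3)nc(NCOCc3ccc(/C=C/C(=O)Nc4ccccc4N)cc3)nc21`, gives 30.4%

Among these three, compound 2 stands highest. Within the data shown here, the only single-point step measured so far is a number 32.9 percentage points higher from compound 1 to compound 2 (beyond the scatter), a change in the linker that carries the (2-aminophenyl)carbamoyl group. Compound 3 stands lower still than compound 1, but it differs from compound 2 in several places at once, so its number shows no single change.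

Compound 4, `Cc1ccc(Nc2nc(Cl)nc3c2ncn3Cc2ccc(C(=O)Nc3ccccc3N)cc2)cc1`, differs from compound 2 by methyl in place of hydrogen on an aromatic carbon. Among the measured compounds shown here, no measured step touches this ring: the step from compound 1 to compound 2 concerns the linker, not the aryl group on the shared core, and compound 3 carries a chloro on that ring alongside other changes. With nothing bearing directly on a methyl at this place, the expectation is a step within the scatter, a number 2.8 percentage points lower from compound 2 to compound 4 (within the scatter). Compound 4 is therefore estimated at 72%, expected between 55% and 85%.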

Compound 4, a percentage reported as inhibition, at one concentration (the size of the read-out at that concentration, not a potency): 82%
For compound 4 the middle estimate is 10 percentage points below the measured one, within the range that was stated.
By their numbers in this assay, from the lowest: compound 3; then compound 1; then compounds 2 and 4 (each within the scatter of the next).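

In this assay, methyl in place of hydrogen on this aromatic carbon gives a number 7.2 percentage points higher from compound 2 to compound 4 (within the scatter), the first step measured on the aryl group of the shared core rather than on the linker. The read-out cannot tell compound 2 and compound 4 apart, so this carbon, para to a large group, accepts a single methyl with no change beyond the scatter, and phenyl and 4-methylphenyl read alike here. Nothing measured here gives a reason for this result.

The compounds shown leave open how a methoxy group, an amine or a longer chain would read at this place, and whether a methyl on another carbon of this ring would read the same. They also leave open whether the same methyl would read alike on the ethenyl linker of compound 1.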